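Dropping a Chloro Group: A Small Change Expected

This account rests on a few compounds, and the source may have more. Where it says the series, first, only, none or still open, it means among the compounds named here.

Compound 1 `CCOC(=O)C1=CCCCC1S(=O)(=O)Cc1ccccc1` and compound 2 `CCOC(=O)C1=CCCCC1S(=O)(=O)Cc1ccc(Cl)cc1F` share the same core and differ only in what sits on the six-membered aromatic ring of carbon only. In a functional assay on RAW264.7 cells (Mus musculus), read by fluorescence (on this read-out higher numbers stand for weaker inhibition and lower numbers for stronger inhibition), compound 1 gives 101 nM, and compound 2 gives 104 nM. Of these two numbers, compound 2 carries the highest, yet its distance to compound 1 lies within the scatter. Compound 3 `CCOC(=O)C1=CCCCC1S(=O)(=O)Cc1ccccc1F` arises from compound 2 by hydrogen in place of chloro on an aromatic carbon. Compound 1 and compound 2 give numbers within the scatter of each other. On that basis the step expected from compound 2 to compound 3 is a 1.0-fold lower number from compound 2 to compound 3 (0.02 log units; within the scatter), none beyond the scatter. Compound 3 is estimated at 100 nM, within a range from 50 nM to 220 nM.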

Compound 3, half-maximal inhibitory concentration: 97 nM
Estimate against measurement, compound 3: 1.0-fold (0.01 log units) above; measured number inside the range.
By their numbers in this assay, from the lowest: compounds 3, 1 and 2 (each within the scatter of the next).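

In this assay, the step for hydrogen in place of chloro, para to a large group, is a 1.1-fold lower number from compound 2 to compound 3 (0.03 log units; within the scatter), so chloro and hydrogen cannot be told apart at this place. The fluoro group can now be read on its own, and its step is a 1.0-fold lower number from compound 1 to compound 3 (0.02 log units; within the scatter), so fluoro in place of hydrogen shows no readable difference either. Nothing on hand gives a reason for these small steps. As far as these compounds go, whether another group at the chloro place, such as an amine, a carboxylic acid or a longer chain, would move the number beyond the scatter remains open.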